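This account rests on a few compounds, and the source may have more. Where it says the series, first, only, none or still open, it means among the compounds named here.

Of the compounds shown here, two sharing one core have been measured in a functional assay for inhibition, with Homo sapiens as the target; a higher number here means a weaker inhibitor, a lower number a stronger inhibitor. Compound 1 `CC(C)(C)Sc1c(CC(C)(C)C(=O)O)n(Cc2ccc(Cl)cc2)c2ccc(OCc3ccc4cc(F)c(F)cc4n3)cc12` gives 7 nM, while compound 2 `CC(C)(C)Sc1c(CC(C)(C)C(=O)O)n(Cc2ccc(Cl)cc2)c2ccc(OCc3nc4ccccc4s3)cc12` gives 3 nM, the lower of the two numbers and so the stronger inhibition. Compound 3 `Cc1nc2ccc(COc3ccc4c(c3)c(SC(C)(C)C)c(CC(C)(C)C(=O)O)n4Cc3ccc(Cl)cc3)cc2s1` is still unmeasured and differs from compound 2 in one place: 2-methyl-1,3-benzothiazol-6-yl in place of 1,3-benzothiazol-2-yl on a saturated chain carbon bound to an oxygen on an aromatic ring. Here 2-methyl-1,3-benzothiazol-6-yl stands in place of 1,3-benzothiazol-2-yl on a saturated chain carbon bound to an oxygen on an aromatic ring. Within the data shown here, only one measured step bears on this place, a 2.3-fold lower number from compound 1 to compound 2 (0.37 log units; beyond the scatter), and it is modest. It involves a different pair of groups, so it is only an indirect guide. A similarly modest rise in the number is therefore expected in this assay, though the direction is uncertain. The expected change is a 2.0-fold higher number from compound 2 to compound 3 (0.30 log units; within the scatter). The estimate for compound 3 is 6 nM, with an expected range of 2 nM to 20 nM.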

Compound 3, half-maximal inhibitory concentration: 6 nM
The estimate for compound 3 equals the measured number at the digits printed, within the range that was stated.
By their numbers in this assay, from the lowest: compounds 2, 3 and 1 (each within the scatter of the next, the first and the last beyond it).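

In this assay, 2-methyl-1,3-benzothiazol-6-yl in place of 1,3-benzothiazol-2-yl gives a 2.0-fold higher number from compound 2 to compound 3 (0.30 log units; within the scatter), so this change does not separate the two compounds. Set against the larger group of compound 1, the same group gives a 1.2-fold lower number from compound 1 to compound 3 (0.07 log units; within the scatter), so the number stays low with a benzothiazole joined through a different ring atom and carrying a methyl, and no gap beyond the scatter opens on either side of compound 3. Nothing available explains these numbers.

From the compounds shown here alone, this step alters the point of attachment and adds the methyl together, so the share of each remains unknown, and the plain 1,3-benzothiazol-6-yl group would be needed to tell them apart. Going by these compounds, it also remains open how a single pyridine ring or an amine would fare on this chain carbon.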